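A Methoxymethyl Group in Place of a Carboxy Group

This account rests on a few compounds, and the source may have more. Where it says the series, first, only, none or still open, it means among the compounds named here.

For the measured compounds named here, compound 1 `Cn1ncc(Cl)c1-c1cc(C(=O)N[C@@H]2CN[C@H](CC(=O)O)C[C@H]2c2ccc(Cl)c(Cl)c2)oc1Cl` is the one member of this small set with a number behind it. Going by the values given here, in a functional assay on LNCaP cells (Homo sapiens) for antiproliferative activity (on this read-out lower numbers stand for stronger inhibition and higher numbers for weaker inhibition), compound 1 gives 640 nM, which is the only value shown and so the sole point of reference. Compound 2 `CC(=O)OCC[C@@H]1C[C@@H](c2ccc(F)c(F)c2)[C@H](NC(=O)c2cc(-c3c(Cl)cnn3C)c(Cl)o2)CN1` shares the core and the amide link, yet in this assay compound 2 has "not determined" (no result reported), so it adds no number to compare against.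

Compound 3 `COCC[C@@H]1C[C@@H](c2ccc(Cl)c(Cl)c2)[C@H](NC(=O)c2cc(-c3c(Cl)cnn3C)c(Cl)o2)CN1` differs from compound 1 in one place: methoxymethyl in place of carboxy on a saturated chain carbon bound to a saturated ring carbon. The change takes away one hydrogen-bond donor while keeping one hydrogen-bond acceptor, on a saturated chain carbon bound to a saturated ring carbon.

Among the compounds with values here, no measured pair shows the effect of this exchange, so the size of the step is open. A change of this kind could in principle move the number either way; with nothing to lean on, the expectation is a step close to none beyond the scatter, a 1.4-fold higher number from compound 1 to compound 3 (0.15 log units; within the scatter), with a wide band around it. Compound 3 is therefore expected to come in at about 900 nM, somewhere between 150 nM and 5000 nM.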

Compound 3, half-maximal inhibitory concentration: 250 nM
The estimate for compound 3 lay 3.6-fold (0.56 log units) above the measured number, and the stated range covers the measured number.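

Replacing carboxy with methoxymethyl on a saturated chain carbon bound to a saturated ring carbon gives a 2.6-fold lower number from compound 1 to compound 3 (0.41 log units; beyond the scatter) in this assay, and on this read-out the lower number means stronger inhibition. The carboxy group at this position is therefore not needed for antiproliferative activity in this pair, and neither is its hydrogen-bond donor, since the entering methoxymethyl has no such donor while both groups keep a hydrogen-bond acceptor. Nothing available explains why the number falls.

This single pair gives the direction and size of one exchange at one position, and compound 2 has no number to extend the comparison, so no further step can be read. Going by these compounds, it remains open how an amine, a free hydroxyl group or a longer ether chain at the same position would behave, and whether the gain from methoxymethyl would hold if another part of the shared core were changed.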